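This account rests on a few compounds, and the source may have more. Where it says the series, first, only, none or still open, it means among the compounds named here.

Compound 1 `COc1cc(-c2nnc3c(OC(C)C)cc(-c4ccc5c(ccn5C)c4)cn23)cc(OC)c1OC`: 402 nM
Compound 2 `COc1cc(-c2nnc3c(OC4CCC4)cc(-c4ccc5c(ccn5C)c4)cn23)cc(OC)c1OC`: 750 nM

Among the compounds with values here, in a functional assay on HCT-116 cells (Homo sapiens) for antiproliferative activity, read by MTT assay, with a stated time of 48 h (on this read-out lower numbers stand for stronger inhibition and higher numbers for weaker inhibition), compound 2 lies within the scatter of compound 1, the only other compound measured. Compound 3 `COc1cc(-c2nnc3c(OC4CC4)cc(-c4ccc5c(ccn5C)c4)cn23)cc(OC)c1OC` differs from compound 2 by one change: cyclopropyl in place of cyclobutyl on an oxygen on an aromatic ring. Within the data shown here, the one measured step that bears on this is a 1.9-fold higher number from compound 1 to compound 2 (0.27 log units; within the scatter), which involves cyclobutyl and isopropyl on the same oxygen. Resting on that small step, no change beyond the scatter is expected in this assay. The estimated step is a 1.4-fold lower number from compound 2 to compound 3 (0.13 log units; within the scatter). For compound 3 the expected value is 550 nM, within an estimated range of 270 nM to 1100 nM.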

Compound 3, half-maximal inhibitory concentration: 135 nM
Compound 3: middle estimate off by 4.1-fold (0.61 log units), on the high side; measured number below the stated range.
By their numbers in this assay, from the lowest: compound 3; then compounds 1 and 2 (each within the scatter of the next).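

In this assay, the group on this oxygen turns out to matter beyond the scatter: the cyclopropyl ether gives a 5.6-fold lower number from compound 2 to compound 3 (0.74 log units; beyond the scatter) and a 3.0-fold lower number from compound 1 to compound 3 (0.47 log units; beyond the scatter). The earlier pair, with cyclobutyl and isopropyl, had shown only a step within the scatter, so cyclopropyl alone stands apart among these three groups. Nothing available accounts for this difference. As far as these compounds go, whether a methyl group, a longer chain or an amine on this oxygen would match cyclopropyl remains open. So does whether the gain holds with any other change to the shared core.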